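Arginine amide in place of aminopropyl on a second core

The compounds below may be only part of what the source reports. "The series", "measured", "known", "first", "only" and "open" are said of these compounds alone.

Two pairs of amides are compared in a functional assay on Ramos cells (Homo sapiens) for cytotoxicity, read by MTT assay, with a stated time of 4 h; on this read-out higher numbers stand for weaker inhibition and lower numbers for stronger inhibition. Compound 1 `CC(C)(C)c1ccc(CC(CN)(Cc2ccc(C(C)(C)C)cc2)C(=O)NCCCN)cc1` gives 14400 nM. Compound 3 `CC(C)(C)c1ccc(CC(CN)(Cc2ccc(C(C)(C)C)cc2)C(=O)N[C@@H](CCCNC(=N)N)C(N)=O)cc1` gives 136000 nM. The change between them is a group of 11 heavy atoms (6 carbon, 4 nitrogen, 1 oxygen; no ring) in place of a group of 4 heavy atoms (3 carbon, 1 nitrogen; no ring), on an amide-type nitrogen, and the step is a 9.4-fold higher number from compound 1 to compound 3 (0.98 log units; beyond the scatter). Compound 2 `NCCCNC(=O)C(CN)(Cc1ccc(C(F)(F)F)cc1)Cc1ccc(C(F)(F)F)cc1` gives 11000 nM, which stands within the scatter of the number for compound 1; the difference between the cores of compound 2 and compound 1 is not broken down here. Compound 4 `N=C(N)NCCC[C@H](NC(=O)C(CN)(Cc1ccc(C(F)(F)F)cc1)Cc1ccc(C(F)(F)F)cc1)C(N)=O` has not been measured in this assay. Its change from compound 2 is a group of 11 heavy atoms (6 carbon, 4 nitrogen, 1 oxygen; no ring) in place of a group of 4 heavy atoms (3 carbon, 1 nitrogen; no ring), on an amide-type nitrogen, the same change as between compound 1 and compound 3, at the same place. The expectation for compound 4 rests on that one measured step: because compound 1 to compound 3 showed a 9.4-fold higher number from compound 1 to compound 3 (0.98 log units; beyond the scatter), a comparable step is expected, namely an 8.6-fold higher number from compound 2 to compound 4 (0.94 log units; beyond the scatter), though a single precedent on a different core leaves the size uncertain. Compound 4 is therefore estimated at 95000 nM, within a range from 30000 nM to 250000 nM.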

Compound 4, half-maximal inhibitory concentration: > 254000 nM
Compound 4 was reported as a limit; the forecaster's own chance of this, stated with the estimate: 10%; middle value at least 2.6-fold (0.42 log units) from the limit.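

In this assay, compound 4 is reported only as a limit, > 254000 nM. Replacing 3-aminopropyl with the arginine amide group gives an at least 23-fold higher number from compound 2 to compound 4 (1.36 log units; beyond the scatter), so the number rises in the same direction on both cores: the same change on two cores in this assay, a 9.4-fold higher number (0.98 log units; beyond the scatter) from compound 1 to compound 3 and an at least 23-fold higher number (1.36 log units; beyond the scatter) from compound 2 to compound 4; the limit leaves it open whether they differ What this does not show is the actual size of the step on the second core or whether the core alters it, and the support is only one pair on each core, with the upper end of the scale reached by a single compound: the limit of > 254000 nM in this assay, at which 1 of the 4 values shown sits.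

The compounds shown leave open which part of the arginine amide group goes with the higher number, since a plain 3-guanidinopropyl chain, a carboxylic acid in place of the primary amide, and a longer amine chain are not among them. They also leave open whether the same direction would hold on cores bearing other groups, such as a methoxy group or a chlorine atom, in place of tert-butyl or trifluoromethyl.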